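Benzyl substitution in the series: compound 2 to compound 3

The compounds below may be only part of what the source reports. "The series", "measured", "known", "first", "only" and "open" are said of these compounds alone.

- compound 1 `COc1ccc(Cc2nnc(NC(=O)/C(C#N)=C/c3ccccc3OS(=O)(=O)c3ccc(C)cc3)s2)cc1`: 25%
- compound 2 `Cc1ccc(S(=O)(=O)Oc2ccccc2/C=C(\C#N)C(=O)Nc2nnc(Cc3ccccc3)s2)cc1`: 16%
- compound 3 `Cc1ccc(S(=O)(=O)Oc2ccccc2/C=C(\C#N)C(=O)Nc2nnc(Cc3cccc(F)c3)s2)cc1`: not yet measured

In a functional assay on HL-60 cells (Homo sapiens) for inhibition, read by CCK-8 assay, with a stated time of 48 h, tested at 20 uM (on this read-out lower numbers stand for less inhibition of growth and higher numbers for more inhibition of growth at the one concentration tested), compound 2 gives 16%, level with compound 1 within the scatter. Compound 3 differs from compound 2 by fluoro in place of hydrogen on an aromatic carbon, benzyl to 3-fluorobenzyl. Among the measured compounds shown here, one measured step bears on this, also a swap on an aromatic carbon: a number 9 percentage points lower from compound 1 to compound 2 (within the scatter). For the measured compounds named here, with only that step as a guide, no change beyond the scatter is expected in this assay. The expected step is a number 3 percentage points higher from compound 2 to compound 3 (within the scatter). Compound 3 is estimated at 19%, with an expected range of 7% to 33%.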

Compound 3, percent growth inhibition at one concentration: 11%
For compound 3 the middle estimate is 8 percentage points above the measured one, and the stated range covers the measured number.
By their numbers in this assay, from the lowest: compounds 3, 2 and 1 (each within the scatter of the next, the first and the last beyond it).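

In this assay, benzyl to 3-fluorobenzyl gives a number 5 percentage points lower from compound 2 to compound 3 (within the scatter), so fluoro on this ring registers no clear change against the unsubstituted benzyl. Replacing 4-methoxyphenyl with 3-fluorophenyl on the chain carbon gives a number 14 percentage points lower from compound 1 to compound 3 (beyond the scatter), the only step shown that clears the scatter, while compound 2 stays within the scatter of both neighbours. Nothing available explains either step.

Open, from the compounds shown here alone, is whether an amine or a carboxylic acid on this ring would move the read-out. A longer chain in place of the benzyl link also remains untested in the compounds shown here.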